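Chalcone series: moving the hydroxyl from 2-hydroxyphenyl to 4-hydroxyphenyl

A few compounds are considered here, and "the series" means these few. Any claim that something is new, unique, unknown or untested is made for them only; others in the source may bear on it.

In a functional assay on RAW264.7 cells (Mus musculus) for inhibition, read by fluorescence, with stated times of 1 h, 24 h and 30 min (on this read-out higher numbers stand for weaker inhibition and lower numbers for stronger inhibition), compound 1 (`O=C(/C=C/c1ccccc1F)c1ccccc1O`) gives > 10000 nM, which is a limit of the assay and not a number. For compound 2 (`O=C(/C=C/c1ccccc1C(F)(F)F)c1ccccc1O`) the entry is "not determined" (no result reported), so it has no number of its own to stand on. Compound 3 is `O=C(/C=C/c1ccccc1C(F)(F)F)c1ccc(O)cc1`. The change 4-hydroxyphenyl in place of 2-hydroxyphenyl on a carbonyl carbon puts 4-hydroxyphenyl in place of 2-hydroxyphenyl on a carbonyl carbon. Among the measured compounds shown here, no measured step sets the size of this change in this assay; a moderate shift toward stronger inhibition is expected, though with low confidence. Compound 3 is estimated at 6000 nM, with an expected range of 1500 nM to 20000 nM.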

Compound 3, half-maximal inhibitory concentration: > 10000 nM
Compound 3 ended at the assay's limit (the forecaster's own chance of this, stated with the estimate: 40%); at least 1.6-fold (0.22 log units) between middle value and limit.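

No step can be read from compound 2 to compound 3, whose result is a limit and not a number: the limit of > 10000 nM in this assay, at which 2 of the 3 values shown sit.

The compounds shown leave open whether 4-hydroxyphenyl in place of 2-hydroxyphenyl changes inhibition at all.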